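Trimming the Amine Tail on a Shared Core

The source may report more compounds than this note shows. Statements on the series, on what has been measured and on what is new or still open speak of the compounds shown alone.

Two measured compounds share the same core and a long chain leading to an amide. Compound 1 `COc1ccc(NC(=O)CCC(=O)OCCCCCCSc2ccc([N+](=O)[O-])c3nonc23)cc1` carries a 4-methoxyphenyl group on the amide nitrogen, and in an assay on isolated protein for inhibition of glutathione S-transferase P (Homo sapiens), with a stated time of 10 min (a lower number here means a stronger inhibitor, a higher number a weaker inhibitor), compound 1 gives 420 nM. Compound 2 `CCN(CC)CCCNC(=O)CCC(=O)OCCCCCCSc1ccc([N+](=O)[O-])c2nonc12` carries a 3-(diethylamino)propyl group there instead; in this assay compound 2 gives 9550 nM, the higher of the two numbers, and the step of a 23-fold higher number from compound 1 to compound 2 (1.36 log units; beyond the scatter) is large. Compound 3 `CN(C)CCNC(=O)CCC(=O)OCCCCCCSc1ccc([N+](=O)[O-])c2nonc12` has not yet been measured; it differs from compound 2 by dimethylamino in place of (diethylamino)methyl on a saturated chain carbon, two bonds along the chain from an amide-type nitrogen. Going by the values given here, the only measured step exchanged an aryl group for an amine chain, whereas this change keeps an amine chain, now 2-(dimethylamino)ethyl, so that step bears on it only loosely. Compound 3 is therefore expected to stay close to compound 2, with an expected step of a 1.0-fold higher number from compound 2 to compound 3 (0.02 log units; within the scatter) inside the scatter. The estimate for compound 3 is 10000 nM, within 4000 nM to 25000 nM.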

Compound 3, half-maximal inhibitory concentration: 540 nM
Compound 3: the middle estimate sits 19-fold (1.27 log units) above what was measured; the whole stated range lies above it.
By their numbers in this assay, from the lowest: compounds 1 and 3 (each within the scatter of the next); then compound 2.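

Within the amine chains, the step of an 18-fold lower number from compound 2 to compound 3 (1.25 log units; beyond the scatter) in this assay shows that this position is sensitive to the exact chain, not just to whether an amine chain is present. Placing 2-(dimethylamino)ethyl on the amide-type nitrogen in place of 4-methoxyphenyl gives a 1.3-fold higher number from compound 1 to compound 3 (0.11 log units; within the scatter) in the same assay, so the 4-methoxyphenyl group is not needed to reach the range of compound 1. Nothing available explains either step.

The step from compound 2 to compound 3 shortens the chain and also replaces the ethyl groups on the amine with methyl groups, so the compounds shown leave open which of the two changes matters. A 3-(dimethylamino)propyl or a 2-(diethylamino)ethyl group would separate them, while a morpholine on an ethyl chain would test a ring-closed amine.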